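The source may hold more compounds than are shown below. What is called first, only, known or untested is meant among the compounds shown, and "the series" means these compounds.

Three compounds have been measured so far in a functional assay on U-251 cells (Homo sapiens) for inhibition, read by MTT assay, with a stated time of 2 days; a lower number here means a stronger inhibitor of growth, a higher number a weaker inhibitor of growth:

- compound 1 `Nc1ccccc1NC(=O)CCCNCC(=O)Nc1ccc(Cl)cc1` gives 11400 nM
- compound 2 `Nc1ccccc1NC(=O)CCCNCC(=O)Nc1ccc(Br)cc1` gives 10400 nM
- compound 3 `Cc1ccc(NC(=O)CNc2ccc(C(=O)Nc3ccccc3N)cc2)cc1` gives 84000 nM

Compound 1 sits level with compound 2, while compound 3 shows a clearly higher number. Compound 4 `COc1ccc(NC(=O)CNCCCC(=O)Nc2ccccc2N)cc1` has not yet been measured. Its change from compound 1 is methoxy in place of chloro on an aromatic carbon, with methoxy in place of chloro on an aromatic carbon, para to a large group. Going by the values given here, the one measured step that bears on this is a 1.1-fold lower number from compound 1 to compound 2 (0.04 log units; within the scatter), bromo in place of chloro, and it lies within the scatter. Among the compounds with values here, no measured step brings in methoxy, so no step beyond the scatter is expected in either direction, though the uncertainty stays wide. The expected step is a 1.1-fold higher number from compound 1 to compound 4 (0.02 log units; within the scatter) on this estimate. For compound 4 the estimated value is 12000 nM with 5000 nM to 30000 nM as the expected range.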

Compound 4, concentration for 50% growth inhibition: 34000 nM
Compound 4: the middle estimate sits 2.8-fold (0.45 log units) below what was measured, and the stated range ends below it.
By their numbers in this assay, from the lowest: compounds 2 and 1 (each within the scatter of the next); then compound 4; then compound 3.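

In this assay, the position para to a large group proves sensitive to the choice of group: chloro and bromo read level, while methoxy gives a 3.0-fold higher number from compound 1 to compound 4 (0.47 log units; beyond the scatter) and a 3.3-fold higher number from compound 2 to compound 4 (0.51 log units; beyond the scatter) in this series. Swapping the substituent here can therefore shift growth inhibition beyond the scatter, though only modestly, and the shift goes toward weaker inhibition. Nothing measured here accounts for this difference.

From the compounds shown here alone, it remains open whether fluoro, methyl or hydroxy at this position would read with the two halogens or with methoxy. Going by these compounds, it is also open whether an amine or a carboxylic acid there would move the number further.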